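The source may hold more compounds than are shown below. What is called first, only, known or untested is meant among the compounds shown, and "the series" means these compounds.

Compound 1 `OC[C@H]1O[C@@H](n2cnc3c(NCc4ccccc4Br)ncnc32)[C@H](O)[C@@H]1O` belongs to a small set of close relatives tested in a functional assay on MCF cells (Homo sapiens) for antiproliferative activity, with a stated time of 72 h; on this read-out higher numbers stand for weaker inhibition and lower numbers for stronger inhibition. In this assay compound 1 gives > 166000 nM, which is a limit of measurement rather than a number. Compound 2 `Cc1ccc(CNc2ncnc3c2ncn3[C@@H]2O[C@H](CO)[C@@H](O)[C@H]2O)cc1` carries a 4-methylphenyl group, and in this assay compound 2 likewise gives only a limit, > 166000 nM. Compound 3 `OC[C@H]1O[C@@H](n2cnc3c(NCc4ccc(Cl)cc4Cl)ncnc32)[C@H](O)[C@@H]1O` carries a 2,4-dichlorophenyl group, and in this assay compound 3 gives 127000 nM. The steps to compound 3 are an at least 1.3-fold lower number from compound 1 to compound 3 (0.11 log units; that floor lies within the scatter) and an at least 1.3-fold lower number from compound 2 to compound 3 (0.11 log units; that floor lies within the scatter), while a step that the two limits leave unreadable from compound 1 to compound 2. Where compound 1 stands is thus fixed only as a ceiling, (the limit of > 166000 nM in this assay, at which 2 of the 3 values shown sit). Compound 4 `OC[C@H]1O[C@@H](n2cnc3c(NCc4ccc(F)cc4Cl)ncnc32)[C@H](O)[C@@H]1O` differs from compound 1 by 2-chloro-4-fluorophenyl in place of 2-bromophenyl on a saturated chain carbon bound to a nitrogen on an aromatic ring. The halogen-bearing relatives, compound 1 and compound 3, bear most on this change, and neither step among the three reached beyond the scatter. The expected step is therefore an at least 1.1-fold lower number from compound 1 to compound 4 (0.04 log units; that floor lies within the scatter), with no direction beyond scatter. Compound 4 is estimated at 150000 nM, expected between 80000 nM and 300000 nM.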

Compound 4, half-maximal inhibitory concentration: > 166000 nM
Compound 4 was reported as a limit; the forecaster's own chance of this, stated with the estimate: 55%; middle value at least 1.1-fold (0.04 log units) from the limit.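

With compound 4 in hand, the one-atom-type swap of fluoro in place of chloro on an aromatic carbon can be looked at alone, and it gives an at least 1.3-fold higher number from compound 3 to compound 4 (0.11 log units; that floor lies within the scatter) in this assay, so neither a real change nor its absence can be claimed. The steps joining compound 4 to compound 1 and to compound 2 cannot be read, as both ends of each are limits. Compound 3 remains the only one of the four with a measured number, and the others gather at one ceiling: the limit of > 166000 nM in this assay, at which 3 of the 4 values shown sit.

From the compounds shown here alone, whether an amine or a carboxylic acid on the phenyl ring would give a number clearly away from that limit stays open. So does whether a longer chain, in place of the saturated chain carbon bound to a nitrogen on an aromatic ring, would move the read-out beyond the scatter.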